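The source may report more compounds than this note shows. Statements on the series, on what has been measured and on what is new or still open speak of the compounds shown alone.

Compound 1, `OCCCCC#Cc1ccccc1C#Cc1ccccn1`: 26100 nM
Compound 2, `COc1cccc(C#Cc2ccccc2C#CCCCCO)c1`: 10700 nM

Both compounds were tested in a functional assay on OVCAR-3 cells (Homo sapiens) for cytotoxicity; a lower number here means a stronger inhibitor of growth, a higher number a weaker inhibitor of growth. Of the two numbers, compound 2 has the lower one, and compound 1 sits at a higher number; the gap between them is beyond the usual scatter of such measurements, so compound 2 is the stronger inhibitor of growth of the pair.

Compound 3, `OCCCCC#Cc1ccccc1C#Cc1cccc(O)c1`, has not yet been measured. It differs from compound 2 in a single place: hydrogen in place of methyl on an oxygen on an aromatic ring. The same difference, cut one bond further out, reads methoxy to hydroxy. Within the data shown here, no pair of measured compounds here differs only in this way, so there is no measured step to lean on, and the expectation rests on the size of the change alone. For compound 3 the expected step from compound 2 in this assay is one that stays within the usual scatter, with no clear direction, namely a 1.1-fold higher number from compound 2 to compound 3 (0.05 log units; within the scatter). For compound 3 the estimated value in this assay is therefore 12000 nM, with a range from 4000 nM to 36000 nM.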

Compound 3, concentration for 50% growth inhibition: 20000 nM
Compound 3: middle estimate off by 1.7-fold (0.22 log units), on the low side, and the stated range covers the measured number.
By their numbers in this assay, from the lowest: compounds 2, 3 and 1 (each within the scatter of the next, the first and the last beyond it).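

In this assay, going from methoxy to hydroxy on the aromatic ring gives a 1.9-fold higher number from compound 2 to compound 3 (0.27 log units; within the scatter), so the methyl on this oxygen makes no difference that can be told apart from the scatter of repeated measurements. A change elsewhere in the molecule, 3-hydroxyphenyl in place of pyridin-2-yl on a triple-bonded carbon, gives a 1.3-fold lower number from compound 1 to compound 3 (0.12 log units; within the scatter), which also stays within that scatter and gives these two groups no clear order in this assay. No additional measurement is available that would explain either result.

Going by these compounds, it remains open whether a larger group on this oxygen, such as ethoxy or benzyloxy, or an amine in place of the hydroxy, would shift the number beyond the scatter. All three compounds share the same chain carrying the alcohol, so the effect of a longer chain or a carboxylic acid in its place is also unknown.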